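This account rests on a few compounds, and the source may have more. Where it says the series, first, only, none or still open, it means among the compounds named here.

Measured in a physicochemical assay for solubility, read by HPLC, using the shake flask method, with a stated time of 2 h, at pH 2; a higher number here means a more soluble compound, a lower number a less soluble compound:
- Compound 1 `Nc1ncc(-c2ccc(C(=O)N3CCC(O)C3)cc2)nc1-c1ccc(C(F)(F)F)cc1`: 129000 nM
- Compound 2 `Nc1ccc(-c2nc(-c3ccc(S(=O)(=O)C4CC4)cc3)cnc2N)cn1`: 212000 nM

Only these two compounds have been measured. Compound 1, with 129000 nM, has the lower number of the pair, but it lies within the usual scatter of compound 2, with 212000 nM, so the two cannot be ranked. They also differ in more than one place, so they offer no single-change step to reason from.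

The next compound, compound 3 `COC(=O)c1ccc(-c2cnc(N)c(-c3ccc(C(F)(F)F)cc3)n2)cc1`, departs from compound 1 by one change: methoxy in place of 3-hydroxypyrrolidin-1-yl on a carbonyl carbon. The same difference reads as (3-hydroxypyrrolidin-1-yl)carbonyl to methoxycarbonyl. Among the compounds with values here, with no measured step as a guide, the expectation rests on this structural change alone, and it is a judgement rather than a measured trend. In this assay, a clear move to a lower number, beyond the scatter, is expected. The expected step is an 8.6-fold lower number from compound 1 to compound 3 (0.93 log units; beyond the scatter). For compound 3 the estimated value is 15000 nM, with an expected range of 3000 nM to 70000 nM.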

Compound 3, solubility: < 5000 nM
Compound 3: a limit, no number; the forecaster's own chance of this, stated with the estimate: 10%; at least 3.0-fold (0.47 log units) between middle value and limit.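

Methoxy in place of 3-hydroxypyrrolidin-1-yl on a carbonyl carbon gives an at least 25-fold lower number from compound 1 to compound 3 (1.41 log units; beyond the scatter), the first single-change step in this series and one that lies beyond the scatter. It shows that, in this assay, the read-out depends strongly on the group held on this carbonyl carbon, something the first two compounds, which differ in more than one place, could not show. Compound 3 gives < 5000 nM, which is a limit and not a number, so the step fixes only a minimum size: the limit of < 5000 nM in this assay, at which 1 of the 3 values shown sits.

The change removes the ring and the hydroxyl together, so the compounds shown leave open which of the two accounts for the step. They also leave open where a plain pyrrolidin-1-yl, a morpholin-4-yl or a carboxylic acid on this carbonyl carbon would fall.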